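The compounds below may be only part of what the source reports. "The series", "measured", "known", "first", "only" and "open" are said of these compounds alone.

In a functional assay on A549 cells (Homo sapiens) for antiproliferative activity, read by MTT assay, with a stated time of 48 h (a higher number here means a weaker inhibitor, a lower number a stronger inhibitor), compound 2 `COC/C1=C/C[C@](C)(CCC=C(C)C)/C=C/[C@@H](OC(=O)C=C(C)C)[C@](C)(O)/C=C/C1=O` gives 3950 nM. Compound 1 `COC/C1=C/C[C@](C)(CCC=C(C)C)/C=C/[C@@H](OC(=O)C=C(C)C)[C@](C)(OC)/C=C/C1=O` gives 4180 nM, and compound 3 `CC(=O)O[C@]1(C)/C=C/C(=O)/C(CO)=C\C[C@](C)(CCC=C(C)C)/C=C/[C@H]1OC(=O)C=C(C)C` gives 3150 nM. All three values lie within the scatter of one another, so compound 2 sits in an unseparated group. Compound 4 `CC(C)=CCC[C@]1(C)/C=C/[C@@H](OC(=O)C=C(C)C)[C@](C)(O)/C=C/C(=O)/C(CN(C(C)C)C(C)C)=C\C1` differs from compound 2 as follows: diisopropylamino in place of methoxy on a saturated chain carbon bound to a double-bonded ring carbon. In words, diisopropylamino stands in place of methoxy on a saturated chain carbon bound to a double-bonded ring carbon. Among the measured compounds shown here, the only measured single-place step, a 1.1-fold lower number from compound 1 to compound 2 (0.02 log units; within the scatter), lies elsewhere, with hydrogen in place of methyl on an oxygen on a saturated carbon, and it stays within the scatter. For the measured compounds named here, no measured step involves the chain carbon, so the series offers only indirect guidance on size or direction there. The close grouping of the three values gives weak support for a small shift. The expected change is a 1.6-fold lower number from compound 2 to compound 4 (0.20 log units; within the scatter), an estimate that carries no firm claim of a shift beyond the scatter. For compound 4 the estimated value is 2500 nM, with an expected range of 800 nM to 7000 nM.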

Compound 4, half-maximal inhibitory concentration: 650 nM
Estimate against measurement, compound 4: 3.8-fold (0.59 log units) above; the measured number lies below the stated range.
By their numbers in this assay, from the lowest: compound 4; then compounds 3, 2 and 1 (each within the scatter of the next).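

In this assay, among the compounds shown here, the saturated chain carbon bound to a double-bonded ring carbon responds to substitution: diisopropylamino in place of methoxy gives a 6.1-fold lower number from compound 2 to compound 4 (0.78 log units; beyond the scatter), whereas the only earlier single-place step, a 1.1-fold lower number from compound 1 to compound 2 (0.02 log units; within the scatter), involved the oxygen on a saturated carbon and stayed within the scatter. The number falls even though the entering group has 7 heavy atoms against 2 in the group that leaves, so this position accepts a much larger group in this assay. No measurement shown here explains the step.

With a single pair at this position, the compounds shown do not separate a contribution of the nitrogen from one of the isopropyl groups. A dimethylamino group and an isopropoxy group at the same place would bear on that question.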